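The source may hold more compounds than are shown below. What is called first, only, known or untested is meant among the compounds shown, and "the series" means these compounds.

Compound 1 has the structure `COc1cc(OC)c2c(=O)cc(C(=O)Nc3ccc(N4CCN(C)CC4)cc3)[nH]c2c1`, with a 4-methylpiperazin-1-yl group on an aromatic carbon. In a functional assay on UoC-B1 cells (Homo sapiens) for antiproliferative activity, with a stated time of 72 h (on this read-out higher numbers stand for an effect only at larger amounts of compound and lower numbers for an effect already at smaller amounts), compound 1 gives only a limit, > 19800 nM. Compound 2 has the structure `COc1cc(OC)c2c(=O)cc(C(=O)Nc3ccc(Oc4ccc(F)cc4)cc3)[nH]c2c1`, with 4-fluorophenoxy in place of that group. In this assay compound 2 also gives only a limit, > 50000 nM. The step that the two limits leave unreadable from compound 1 to compound 2 cannot be read in size, because both of its ends are limits. the limit of > 19800 nM in this assay, at which 1 of the 2 values shown sits, is where compound 1 sits. the limit of > 50000 nM in this assay, at which 1 of the 2 values shown sits, is where compound 2 sits. Compound 3 has the structure `COc1cc(OC)c2c(=O)cc(C(=O)Nc3ccc(Oc4cccnc4)cc3)[nH]c2c1` and differs from compound 2 by pyridin-3-yl in place of 4-fluorophenyl on an oxygen on an aromatic ring. No measured step covers this exchange, and the one step that is shown is unreadable, so nothing among the measured compounds points to a direction. Compound 2 stands at a limit, and compound 3 is expected to stay close to it, with the expected step of a number no higher from compound 2 to compound 3 (the limit leaves the size open) being none beyond the scatter. For compound 3 in this assay the estimate is 50000 nM, in a range from 12000 nM to 200000 nM, and most probably again reported only as a limit.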

Compound 3, half-maximal effective concentration: 27700 nM
Beside the measured number, compound 3's estimate is 1.8-fold (0.26 log units) above it, and the stated range covers the measured number.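

Compound 3, with pyridin-3-yl in place of 4-fluorophenyl on an oxygen on an aromatic ring, is the only one of the three compounds shown that gives a number rather than a limit in this assay, so this place can carry a group that brings a measurable effect into the range of the assay. The exchange amounts to an at least 1.8-fold lower number from compound 2 to compound 3 (0.25 log units; that floor lies within the scatter), and because compound 2 has only a limit at that end, the real size of the step remains unknown and could be no more than scatter or could be considerably larger: the limit of > 50000 nM in this assay, at which 1 of the 3 values shown sits. The steps that start from compound 1 cannot be read, and nothing measured here says what lies behind the change.

The exchange removes the fluorine and brings in a ring nitrogen at once, so a plain phenyl on the same oxygen would be needed to tell these two parts apart. Going by these compounds, it also remains open whether pyridin-4-yl or pyridin-2-yl would give a number like that of compound 3, and whether a ring carrying an amine or a carboxylic acid would move it further.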